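Removing a Methoxy Group: What to Expect for Compound 3

This account rests on a few compounds, and the source may have more. Where it says the series, first, only, none or still open, it means among the compounds named here.

Of the compounds shown here, two sharing one core have been measured so far. Compound 1 `COc1cccc2c1OCN(c1ccc3oc(-c4ccccc4)cc(=O)c3c1)C2` stands highest of the pair: in a functional assay on MCF7 cells (Homo sapiens) for inhibition, read by MTT assay, with a stated time of 48 h, tested at 15 ug/mL (on this read-out lower numbers stand for less inhibition of growth and higher numbers for more inhibition of growth at the one concentration tested), compound 1 gives 54%. Compound 2 `O=c1cc(-c2ccccc2)oc2cc(N3COc4c(cccc4[N+](=O)[O-])C3)ccc12` in this assay gives 1.96%, a number lying well below that of compound 1, a gap beyond the usual scatter. Compound 3 `O=c1cc(-c2ccccc2)oc2ccc(N3COc4ccccc4C3)cc12` has not yet been measured. It differs from compound 1 by hydrogen in place of methoxy on an aromatic carbon. For the measured compounds named here, no step between two measured compounds shows directly what removing this group does here, so the expectation rests on compound 1 alone. The step is expected to be moderate and toward less inhibition, a number 14 percentage points lower from compound 1 to compound 3 (beyond the scatter), probably close to the edge of the scatter. Compound 3 is therefore estimated at 40%, with a range from 15% to 62%.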

Compound 3, percent growth inhibition at one concentration: 34%
For compound 3 the middle estimate is 6 percentage points above the measured one; the range from low to high includes it.
By their numbers in this assay, from the lowest: compound 2; then compound 3; then compound 1.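

In this assay, for the compounds shown here, putting hydrogen in place of methoxy on this aromatic carbon gives a modest loss, a number 20 percentage points lower from compound 1 to compound 3 (beyond the scatter), the first change at a single place that can be read on its own. Compound 3 still gives 34%, so inhibition of growth at this concentration does not depend entirely on the methoxy group, although the compound carrying it gives the higher number. Nothing available explains why the number falls.

Still open, on these data alone, is how other groups on this same carbon would compare: an ethoxy group, a longer ether chain or an amine could land above compound 1, below compound 3 or between them. It is also unknown whether the step would keep its size at other concentrations, since only one was tested.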